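A few compounds are considered here, and "the series" means these few. Any claim that something is new, unique, unknown or untested is made for them only; others in the source may bear on it.

Among the measured compounds shown here, in a functional assay on SEM cells (Homo sapiens) for inhibition, read by MTT assay, with a stated time of 72 h (a lower number here means a stronger inhibitor, a higher number a weaker inhibitor), compound 1 (`COc1cccc(/C=C/C(=O)Nc2cc(OC)c(OC)c(OC)c2)c1`) gives 18200 nM and stands highest of the two numbers measured so far, which makes it the weaker inhibitor of the pair. Compound 2 (`C=C(Br)C(=O)Nc1cccc(/C=C/C(=O)Nc2ccc(F)cc2)c1`) gives 8400 nM in this assay and so sits lower, by a gap beyond the usual scatter. For the measured compounds named here, no two measured compounds differ in just one place, so nothing measured yet shows directly what a single swap does here. Compound 3 (`COc1cc(NC(=O)/C=C/c2cccc(N)c2)cc(OC)c1OC`) is compound 1 with amino in place of methoxy on an aromatic carbon, meta to a large group (amino in place of methoxy on an aromatic carbon), which reads as 3-methoxyphenyl to 3-aminophenyl. The expected step (a 1.5-fold lower number from compound 1 to compound 3 (0.18 log units; within the scatter)) is small, a slight fall in the number that stays within the usual scatter. For compound 3 the estimated half-maximal inhibitory concentration is 12000 nM with an expected range from 4000 nM to 35000 nM in this assay when it is measured.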

Compound 3, half-maximal inhibitory concentration: 2810 nM
For compound 3 the middle estimate is 4.3-fold (0.63 log units) above the measured one; measured number below the stated range.
By their numbers in this assay, from the lowest: compound 3; then compound 2; then compound 1.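

In this assay, among the compounds shown here, the first single-place change in this set gives a 6.5-fold lower number from compound 1 to compound 3 (0.81 log units; beyond the scatter), and that step lies beyond the scatter. So the group on this aromatic carbon, meta to a large group, is not a silent spot on the core: the number responds when one group replaces another, with the rest of the molecule unchanged. The swap exchanges methoxy for amino, a smaller group by heavy-atom count that adds a hydrogen-bond donor, but nothing measured here separates these differences or says why the number falls.

On these data alone, it remains open whether a hydroxyl, a methylamino or a dimethylamino group on the same carbon would track amino or methoxy. Also open, as far as these compounds go, is whether amino in place of methoxy would give a similar step on a different core.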